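Two methyls in place of a chlorine on the anilide

A few compounds are considered here, and "the series" means these few. Any claim that something is new, unique, unknown or untested is made for them only; others in the source may bear on it.

Compound 1 `Cc1ccccc1NS(=O)(=O)c1ccc(N2CCNC2=O)cc1` gives 150 nM in a functional assay on M21 cells (Homo sapiens) for antiproliferative activity, read by sulforhodamine B assay, with a stated time of 48 h; a lower number here means a stronger inhibitor, a higher number a weaker inhibitor; compound 2 `Cc1cccc(NS(=O)(=O)c2ccc(N3CCNC3=O)cc2)c1C` gives 110 nM; compound 3 `O=C1NCCN1c1ccc(S(=O)(=O)Nc2cccc(Cl)c2)cc1` gives 25 nM.

Compound 3 stands lowest of the three, ahead of compound 2 by a 4.4-fold lower number from compound 2 to compound 3 (0.64 log units; beyond the scatter) and of compound 1 by a 6.0-fold lower number from compound 1 to compound 3 (0.78 log units; beyond the scatter). Compound 4 `Cc1ccc(NS(=O)(=O)c2ccc(N3CCNC3=O)cc2)cc1C` differs from compound 3 by 3,4-dimethylphenyl in place of 3-chlorophenyl on a sulfonamide nitrogen. The two steps that bear on this both run from a methyl-bearing phenyl toward the 3-chlorophenyl and lower the number; here the change runs the other way. Compound 4 is therefore expected to show a modestly higher number, a step of a 3.2-fold higher number from compound 3 to compound 4 (0.51 log units; beyond the scatter). Compound 4 is estimated at 80 nM, with a range from 30 nM to 200 nM.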

Compound 4, half-maximal inhibitory concentration: 94 nM
The estimate for compound 4 lay 1.2-fold (0.07 log units) below the measured number; the measured number falls inside the stated range.
By their numbers in this assay, from the lowest: compound 3; then compounds 4, 2 and 1 (each within the scatter of the next).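

In this assay the change to 3,4-dimethylphenyl brings a 3.8-fold higher number from compound 3 to compound 4 (0.58 log units; beyond the scatter) and so shows that a third methyl-bearing phenyl on the sulfonamide nitrogen also stays short of 3-chlorophenyl. Among these three methyl-bearing phenyls, the number and arrangement of the methyls make no readable difference, with a 1.2-fold lower number from compound 2 to compound 4 (0.07 log units; within the scatter) and a 1.6-fold lower number from compound 1 to compound 4 (0.20 log units; within the scatter) both within the scatter. Nothing measured here accounts for the separation of the 3-chlorophenyl compound. On these data alone, whether the lower number belongs to chlorine itself stays open, and a fluorine, methoxy, trifluoromethyl or amine in its place would bear on that.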